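Cyano for Methylsulfonyl on a Shared Acylsulfonamide Core

This account rests on a few compounds, and the source may have more. Where it says the series, first, only, none or still open, it means among the compounds named here.

Compound 2 `CN(C)CC[C@H](CSc1ccccc1)Nc1ccc(S(=O)(=O)NC(=O)c2ccc(N3CCN(Cc4ccccc4-c4ccc(Cl)cc4)CC3)cc2)cc1S(C)(=O)=O` is measured in an assay on isolated protein for displacement of a labelled ligand from Bcl2-associated agonist of cell death (Homo sapiens), read by fluorescence polarization (on this read-out higher numbers stand for weaker inhibition and lower numbers for stronger inhibition), where compound 2 gives < 1 nM, a limit of the assay rather than a number. Compound 1 `CN(C)CC[C@H](CSc1ccccc1)Nc1ccc(S(=O)(=O)NC(=O)c2ccc(N3CCN(CC4=C(c5ccc(Cl)cc5)CCC4)CC3)cc2)cc1[N+](=O)[O-]` likewise reaches only a limit there, giving < 1 nM. Both values thus sit at the limit of < 1 nM in this assay, at which 2 of the 2 values shown sit. Compound 3 `CN(C)CC[C@H](CSc1ccccc1)Nc1ccc(S(=O)(=O)NC(=O)c2ccc(N3CCN(Cc4ccccc4-c4ccc(Cl)cc4)CC3)cc2)cc1C#N` differs from compound 2 by cyano in place of methylsulfonyl on an aromatic carbon. No measured step joins two compounds here, so no size of change is shown. Compound 3 is expected to stay near the limit, the step that the limit leaves unreadable from compound 2 to compound 3 being expected to be none beyond the scatter. Compound 3 is therefore estimated at 0.5 nM, between 0.1 nM and 3 nM.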

Compound 3, inhibition constant: < 1 nM
Compound 3: no number, only a limit (the forecaster's own chance of this, stated with the estimate: 70%); the middle value does not contradict the limit.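

The step from compound 2 to compound 3 cannot be read, because in this assay both stop at a limit: the limit of < 1 nM in this assay, at which 3 of the 3 values shown sit. Left open is whether cyano and methylsulfonyl differ at all on the shared core, and how strongly compounds 1, 2 and 3 actually inhibit.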